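This account rests on a few compounds, and the source may have more. Where it says the series, first, only, none or still open, it means among the compounds named here.

In a functional assay on HeLa cells (Homo sapiens) for antiproliferative activity, read by spectrophotometry, with a stated time of 2 days (a higher number here means a weaker inhibitor of growth, a lower number a stronger inhibitor of growth), compound 1 `COc1ccc(Nc2ncc(C(F)(F)F)c(N3Cc4cccc(N(C)S(C)(=O)=O)c4C3)n2)cc1C(F)(F)F` gives 14000 nM. Compound 2 `Cc1ccc(Nc2ncc(C(F)(F)F)c(N3Cc4cccc(N(C)S(C)(=O)=O)c4C3)n2)cc1C` gives only a limit, > 30000 nM. Compound 3 `Cc1cc(Cl)ccc1Nc1ncc(C(F)(F)F)c(N2Cc3cccc(N(C)S(C)(=O)=O)c3C2)n1` gives 17400 nM, which leaves it level with compound 1: the measured step is a 1.2-fold higher number from compound 1 to compound 3 (0.09 log units; within the scatter). Compound 4 `CN(c1cccc2c1CN(c1nc(Nc3cccc(C(F)(F)F)c3)ncc1C(F)(F)F)C2)S(C)(=O)=O` differs from compound 3 as follows: 3-(trifluoromethyl)phenyl in place of 4-chloro-2-methylphenyl on a nitrogen on an aromatic ring, with 3-(trifluoromethyl)phenyl in place of 4-chloro-2-methylphenyl on a nitrogen on an aromatic ring. Exchanges at this place gave an at least 2.1-fold higher number from compound 1 to compound 2 (0.33 log units; beyond the scatter) and an at least 1.7-fold lower number from compound 2 to compound 3 (0.23 log units; that floor lies within the scatter). The nearest group stands in compound 1, which carries 4-methoxy-3-(trifluoromethyl)phenyl and gives 14000 nM. An estimated 1.1-fold lower number from compound 3 to compound 4 (0.04 log units; within the scatter) is therefore expected, with no change beyond the scatter. Compound 4 is expected at 16000 nM, within an estimated range of 7000 nM to 30000 nM.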

Compound 4, concentration for 50% growth inhibition: 5300 nM
The estimate for compound 4 lay 3.0-fold (0.48 log units) above the measured number; the whole stated range lies above it.
By their numbers in this assay, from the lowest: compound 4; then compounds 1 and 3 (each within the scatter of the next). At a limit, above all of these: compound 2.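

Going by these compounds alone, with hydrogen in place of methoxy on an aromatic carbon, the 3-(trifluoromethyl)phenyl group gives the first step at this place that lowers the number beyond the scatter between two measured numbers: a 2.6-fold lower number from compound 1 to compound 4 (0.42 log units; beyond the scatter). Against the 4-chloro-2-methylphenyl group, the drop is of similar size, a 3.3-fold lower number from compound 3 to compound 4 (0.52 log units; beyond the scatter). The step of an at least 5.6-fold lower number from compound 2 to compound 4 (0.75 log units; beyond the scatter) is only a floor, its starting value being a limit and not a number: the limit of > 30000 nM in this assay, at which 1 of the 4 values shown sits.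

From the compounds shown here alone, what a plain phenyl, or a nitrile or carboxylic acid in place of trifluoromethyl, would give at this place remains open. So does whether the 3-(trifluoromethyl)phenyl gain would hold on another core.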